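Swapping the distal sulfamoyl in a piperidine ester series

This account rests on a few compounds, and the source may have more. Where it says the series, first, only, none or still open, it means among the compounds named here.

Measured so far:
- Compound 1 `CCOC(=O)[C@@H]1CCCN(S(=O)(=O)c2ccc(S(=O)(=O)N(CC)CC)nc2)C1`: in a functional assay on MIA PaCa-2 cells (Homo sapiens) for inhibition, read by MTT assay, with a stated time of 7 days (a lower number here means a stronger inhibitor, a higher number a weaker inhibitor), compound 1 gives 5600 nM
- Compound 2 `CCOC(=O)[C@@H]1CCCN(S(=N)(=O)c2ccc(S(=O)(=O)N(CC)CC)cc2)C1`: in this assay compound 2 gives 12100 nM
- Compound 3 `CCOC(=O)[C@@H]1CCCN(S(=O)(=O)c2ccc(S(=O)(=O)N(CC)C(C)C)cc2)C1`: in this assay compound 3 gives 1000 nM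

Compound 3 has the lowest number of the three. Its nearest neighbour is compound 1, whose number is higher by a gap beyond the scatter; compound 2 sits furthest away, also beyond the scatter. No two of these compounds differ in a single place, so no single change can be isolated from them.

Compound 4, `CCOC(=O)[C@@H]1CCCN(S(=O)(=O)c2ccc(S(=N)(=O)N(CC)CC)cc2)C1`, has not yet been measured. Set against compound 3, the change is a group of 8 heavy atoms (4 carbon, 2 nitrogen, 1 oxygen, 1 sulfur; no ring) in place of a group of 9 heavy atoms (5 carbon, 1 nitrogen, 2 oxygen, 1 sulfur; no ring), on an aromatic carbon. The group that enters carries one hydrogen-bond donor where the group that leaves has none, and sits para to a large group on the six-membered aromatic ring of carbon only.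

Compound 2 already shows that a related nitrogen-for-oxygen change on a sulfur, elsewhere in the shared core, goes with the weakest number of the set. On that basis the step from compound 3 to compound 4 is expected to raise the number in this assay by an 8.0-fold higher number from compound 3 to compound 4 (0.90 log units; beyond the scatter), beyond the scatter. Compound 4 is therefore expected to give 8000 nM, within 2500 nM to 25000 nM.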

Compound 4, half-maximal inhibitory concentration: 2600 nM
Estimate against measurement, compound 4: 3.1-fold (0.49 log units) above, and the stated range covers the measured number.
By their numbers in this assay, from the lowest: compound 3; then compound 4; then compound 1; then compound 2.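

In this assay, among the compounds shown here, the change at this position gives the first step that can be read: a 2.6-fold higher number from compound 3 to compound 4 (0.41 log units; beyond the scatter), a modest rise that lies beyond the scatter. The ethyl(isopropyl)sulfamoyl group, on an aromatic carbon and para to a large group, can thus be replaced by a group carrying a hydrogen-bond donor with only this modest loss, and the hydrogen-bond acceptor count, the double bonds outside aromatic rings and the absence of net charge stay as they were. The entering group differs from the leaving one in its carbon, nitrogen and oxygen counts at once, so the step cannot be assigned to any one of these differences, and no measurement shown gives a reason for the shift.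

The compounds shown leave open how a simpler group at this position, such as methylsulfonyl or a primary amine, would read in this assay. They also leave open whether the step would keep its size if the ethyl ester of the shared core gave way to a carboxylic acid.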